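Chloro for Methyl: What Compound 3 Is Expected to Show

The source may hold more compounds than are shown below. What is called first, only, known or untested is meant among the compounds shown, and "the series" means these compounds.

Compound 1 `Cc1ccc(-c2n[nH]c3c2CCNCC3)cc1` has been characterised in an assay on cells for displacement of a labelled ligand from 5-hydroxytryptamine receptor 5A (Homo sapiens), read by scintillation counting, with a stated time of 1.5 h (a higher number here means a weaker inhibitor, a lower number a stronger inhibitor), only as a limit. In this assay compound 1 gives > 10000 nM, which is a limit of the assay and not a number. The second measured compound, compound 2 `Clc1ccc(-c2noc3c2CCNCC3)cc1`, shares a different core but carries the same chloro group that is about to be introduced. In this assay compound 2 also gives > 10000 nM, again a limit rather than a number. Going by the values given here, both values therefore sit at the limit of > 10000 nM in this assay, at which 2 of the 2 values shown sit, and no step between the two measured compounds can be given.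

The unmeasured compound 3 `Clc1ccc(-c2n[nH]c3c2CCNCC3)cc1` is reached from compound 1 by chloro in place of methyl on an aromatic carbon. Because compound 1 gives > 10000 nM and nothing sharper, the step can only be judged against that limit. The step that the limit leaves unreadable from compound 1 to compound 3 is expected to be none beyond the scatter, with compound 3 most likely remaining at the limit. Compound 3 is therefore estimated at 20000 nM in this assay, with a range from 5000 nM to 100000 nM.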

Compound 3, inhibition constant: > 10000 nM
Compound 3: no number, only a limit; the forecaster's own chance of this, stated with the estimate: 80%; the middle value is on the limit's open side.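

In this assay compound 3 gives > 10000 nM, which is a limit of the assay and not a number. No step can be read between compound 1 and compound 3, as both stand at the same limit: the limit of > 10000 nM in this assay, at which 3 of the 3 values shown sit. The compounds shown leave open what chloro in place of methyl does to a measurable value in this assay.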